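Swapping an Azetidine Ether for a Cyanopyridine Ether

The source may hold more compounds than are shown below. What is called first, only, known or untested is meant among the compounds shown, and "the series" means these compounds.

Compound 1 `CCn1cnc2c(-c3ccnc(Oc4ccccc4)c3)cnnc21`: 2.6
Compound 2 `CC(=O)N1CC(Oc2cc(-c3cnnc4c3ncn4C(C)C)ccc2F)C1`: 1.6

In a physicochemical assay for lipophilicity (a lower number here means a more polar compound, a higher number a more lipophilic compound), compound 2 stands lowest of the two numbers; its nearest neighbour, compound 1, reads higher by a margin beyond the usual scatter. Compound 3 `CC(C)n1cnc2c(-c3ccc(F)c(Oc4ccc(C#N)cn4)c3)cnnc21` has not yet been measured. It differs from compound 2 by 5-cyanopyridin-2-yl in place of 1-acetylazetidin-3-yl on an oxygen on an aromatic ring. Among the compounds with values here, no measured pair shows this exact change, so the only guide is that compound 1 gives 2.6 whereas compound 2 gives 1.6. An upward step is expected, a number 1.20 log units higher from compound 2 to compound 3 (beyond the scatter), beyond the scatter. Compound 3 is estimated at 2.8, with a range from 2.3 to 3.3.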

Compound 3, distribution coefficient: 2.7
Estimate against measurement, compound 3: 0.10 log units above, and the stated range covers the measured number.
By their numbers in this assay, from the lowest: compound 2; then compounds 1 and 3 (each within the scatter of the next).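

On an oxygen on an aromatic ring, this assay now gives a clean reading of one change: 5-cyanopyridin-2-yl in place of 1-acetylazetidin-3-yl brings a number 1.10 log units higher from compound 2 to compound 3 (beyond the scatter). The two earlier compounds differ in more than one place, so they could not isolate this change. Nothing available explains the size of the step. One pair cannot show whether the step would hold on a different core. Where a group carrying an amine or a carboxylic acid on this oxygen would fall also remains open.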